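The source may hold more compounds than are shown below. What is called first, only, known or untested is meant among the compounds shown, and "the series" means these compounds.

In a functional assay on Rec1 cells (Homo sapiens) for inhibition, read by luminescence and CellTiter-Glo, with a stated time of 72 h (a higher number here means a weaker inhibitor, a lower number a stronger inhibitor), compound 1 (`O=C(CCl)Nc1ccc(Cn2nc(-c3ccc(Oc4ccccc4)cc3)cc2C(=O)O)cc1`) gives 4000 nM and compound 2 (`O=C(CCl)Nc1cccc(Cn2nc(-c3ccc(Oc4ccccc4)cc3)cc2C(=O)O)c1`) gives 7100 nM, two values within the scatter of each other. Compound 3 (`C=CC(=O)Nc1cccc(Cn2nc(-c3ccc(Oc4ccccc4)cc3)cc2C(=O)O)c1`) has vinyl in place of chloromethyl on a carbonyl carbon. Within the data shown here, no measured step makes this swap. The only measured one, a 1.8-fold higher number from compound 1 to compound 2 (0.25 log units; within the scatter), is a different change, 3-(((chloromethyl)carbonyl)amino)phenyl in place of 4-(((chloromethyl)carbonyl)amino)phenyl, so it offers only a rough guide to size and none to direction. The expected step is a 1.3-fold higher number from compound 2 to compound 3 (0.10 log units; within the scatter), nothing beyond the scatter. Compound 3 is estimated at 9000 nM, with a wide range of 3000 nM to 25000 nM.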

Compound 3, half-maximal inhibitory concentration: 33100 nM
Compound 3: the middle estimate sits 3.7-fold (0.57 log units) below what was measured; measured number above the stated range.
By their numbers in this assay, from the lowest: compounds 1 and 2 (each within the scatter of the next); then compound 3.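

In this assay, vinyl in place of chloromethyl on the carbonyl carbon costs clearly more than the earlier swap of 4- for 3-substitution on the phenyl, which stayed within the scatter: a 4.7-fold higher number from compound 2 to compound 3 (0.67 log units; beyond the scatter). With both changes together, the gap widens to an 8.3-fold higher number from compound 1 to compound 3 (0.92 log units; beyond the scatter). Nothing available explains this loss. Still open, on these data alone, is whether vinyl gives the same loss on the 4-substituted phenyl of compound 1, and how bromomethyl or a longer carbon chain on that carbonyl carbon would compare.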